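The source may report more compounds than this note shows. Statements on the series, on what has been measured and on what is new or still open speak of the compounds shown alone.

Measured in an ADME assay (liver) for metabolic stability, with Liver microsome (Rattus norvegicus) as the target, using microsomes; on this read-out higher numbers stand for fast clearance and lower numbers for slow clearance:
- compound 1 `CN(C(=O)c1cc(-c2ccccn2)[nH]n1)c1ccc(OCB2C=Cc3ccccc3N2)cc1`: 25 mL/min/kg
- compound 2 `Cn1cc(-c2ccncc2)c(-c2ccc(OCc3ccc4ccccc4c3)cc2)n1`: 83.3 mL/min/kg
- compound 3 `CN(C(=O)c1cc(-c2ccccn2)[nH]n1)c1ccc(OCc2ccc3ccccc3c2)cc1`: 30 mL/min/kg

Compound 3, at 30 mL/min/kg, lies within the scatter of compound 1 and beyond the scatter under compound 2, which gives 83.3 mL/min/kg. Compound 4 `CN(C(=O)c1ccncc1)c1ccc(OCc2ccc3ccccc3c2)cc1` carries pyridin-4-yl in place of 5-(pyridin-2-yl)-1H-pyrazol-3-yl on a carbonyl carbon.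

Within the data shown here, no measured step covers a change at this place. The only one, a 1.2-fold higher number from compound 1 to compound 3 (0.08 log units; within the scatter), lies on a saturated chain carbon bound to an oxygen on an aromatic ring and stays within the scatter, so it says little here. Compound 2 also carries a pyridin-4-yl and gives 83.3 mL/min/kg, which tilts the expectation slightly upward, although compound 2 differs from compound 3 in more than this group. In this assay the expected move is a 1.3-fold higher number from compound 3 to compound 4 (0.12 log units; within the scatter), not clearly beyond the scatter. For compound 4 the estimate is 40 mL/min/kg, with an expected range of 17 mL/min/kg to 90 mL/min/kg.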

Compound 4, clearance: 75 mL/min/kg
The estimate for compound 4 lay 1.9-fold (0.27 log units) below the measured number; low and high end bracket the measured number.
By their numbers in this assay, from the lowest: compounds 1 and 3 (each within the scatter of the next); then compounds 4 and 2 (each within the scatter of the next).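

In this assay, the group on the carbonyl carbon proves sensitive: pyridin-4-yl in place of 5-(pyridin-2-yl)-1H-pyrazol-3-yl gives a 2.5-fold higher number from compound 3 to compound 4 (0.40 log units; beyond the scatter). Of the two single-place steps in the series, only this one lies beyond the scatter, since a 1.2-fold higher number from compound 1 to compound 3 (0.08 log units; within the scatter) at the saturated chain carbon does not. The change removes the five-membered aromatic ring and the hydrogen-bond donor together, so the step cannot be assigned to either, and no measured data bear on its cause.

On these data alone, it remains open whether a plain 1H-pyrazol-3-yl or a phenyl on the carbonyl carbon would give a number closer to that of compound 3 or compound 4. As far as these compounds go, it is also open whether the step at the saturated chain carbon stays within the scatter with pyridin-4-yl on the carbonyl carbon.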